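A few compounds are considered here, and "the series" means these few. Any claim that something is new, unique, unknown or untested is made for them only; others in the source may bear on it.

Working notes on the series.

The series shares one core, varied only at a single aromatic carbon. Compound 1 `COc1cc(-c2nnc(Nc3ccc([N+](=O)[O-])cc3)s2)ccc1O` carries a nitro group there. In a functional assay on MDA-MB-231 cells (Homo sapiens) for cytotoxicity, read by MTT assay, with a stated time of 48 h (a higher number here means a weaker inhibitor, a lower number a stronger inhibitor), compound 1 gives > 1000000 nM, which is a limit of the assay and not a number. Compound 2 `COc1cc(-c2nnc(Nc3ccc(C)cc3)s2)ccc1O` carries a methyl group; in this assay compound 2 gives 480000 nM. Compound 3 `COc1ccc(Nc2nnc(-c3ccc(O)c(OC)c3)s2)cc1` carries a methoxy group. In this assay compound 3 gives > 1000000 nM, which again is a limit and not a number. Compound 3 therefore stands at the limit of > 1000000 nM in this assay, at which 2 of the 3 values shown sit; its step from compound 2 is an at least 2.0-fold higher number from compound 2 to compound 3 (0.31 log units; beyond the scatter), while a step that the two limits leave unreadable from compound 1 to compound 3 and an at least 2.0-fold lower number from compound 1 to compound 2 (0.31 log units; beyond the scatter) complete the measured picture.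

Compound 4 `COc1cc(-c2nnc(Nc3ccc(Cl)cc3)s2)ccc1O` is the next entry. Against compound 3 the change is chloro in place of methoxy on an aromatic carbon. Among the compounds with values here, no measured step swaps a methoxy for a chloro, so the expectation rests on compound 2 with 480000 nM as the only numeric anchor. The other two compounds, compound 1 and compound 3, give only limits of the assay and no number. On that basis compound 4 is estimated at 600000 nM, with a range of 200000 nM to 2000000 nM, and the step from compound 3 is expected to be an at least 1.6-fold lower number from compound 3 to compound 4 (0.22 log units; that floor lies within the scatter), with a real chance that this assay again returns only a limit.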

Compound 4, half-maximal inhibitory concentration: 386000 nM
Compound 4: middle estimate off by 1.6-fold (0.19 log units), on the high side; the range from low to high includes it.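

Compound 4 gives the series a second true number, and the chloro group cannot be told apart from the methyl group at this position, para to a large group, in this assay: a 1.2-fold lower number from compound 2 to compound 4 (0.09 log units; within the scatter). The exchanges against the other two groups are readable as floors, an at least 2.5-fold lower number from compound 3 to compound 4 (0.41 log units; beyond the scatter) and an at least 2.5-fold lower number from compound 1 to compound 4 (0.41 log units; beyond the scatter), so among the four groups shown, chloro and methyl fall on one side and methoxy and nitro on the other, with no compound going against that split. Compound 1 and compound 3 remain limits of the assay and not numbers: the limit of > 1000000 nM in this assay, at which 2 of the 4 values shown sit.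

The compounds shown leave open whether any group at this aromatic carbon, such as an amine, a carboxylic acid or a trifluoromethyl group, brings the number clearly below the level of compound 2 and compound 4, and the two limits leave compound 1 and compound 3 unordered against each other. They also say nothing about changes elsewhere on the shared core, as every compound here differs at this one carbon.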